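Methyl to Hydrogen at the Amine Arm: Cytotoxicity Outlook

The compounds below may be only part of what the source reports. "The series", "measured", "known", "first", "only" and "open" are said of these compounds alone.

Compound 1 `COc1ccc(Cn2c(C(=O)N3CCC(C(=O)NCc4ccccc4)CC3)cc3sccc32)cc1` and compound 2 `COc1ccc(Cn2c(C(=O)N3CCC(C(=O)NC(C)c4ccccc4)CC3)cc3sccc32)cc1` share a core whose side arm is joined through an amide, while compound 3 `CCCNC(=O)C1CCN(C(=O)c2c(CNC(C)c3ccccc3)c3sccc3n2Cc2ccc(OC)cc2)CC1` carries its side arm through an amine and a propylcarbamoyl group elsewhere; the difference between the two cores is not broken down here. In an ADME assay on HEK-293T cells (Homo sapiens) for cytotoxicity, read by luminescence, with a stated time of 24 h (on this read-out lower numbers stand for higher toxicity in this test and higher numbers for lower toxicity in this test), compound 1 reaches only the limit of the test, > 100000 nM. Compound 2 also returns a limit in this assay, > 100000 nM. Going by the values given here, compound 3 is the one compound of the three that gives a number in this assay, 57500 nM. The change hydrogen in place of methyl on a saturated chain carbon bound to an amide-type nitrogen and an aromatic carbon produced a step that the two limits leave unreadable from compound 2 to compound 1, since both values sit at the limit of > 100000 nM in this assay, at which 2 of the 3 values shown sit, and the size cannot be read.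

Compound 4 `CCCNC(=O)C1CCN(C(=O)c2c(CNCc3ccccc3)c3sccc3n2Cc2ccc(OC)cc2)CC1` differs from compound 3 by hydrogen in place of methyl on a saturated chain carbon bound to an amine nitrogen and an aromatic carbon. This is the same kind of change as that from compound 2 to compound 1, but the place is not identical: in the measured pair the carbon is bound to an amide-type nitrogen, whereas in compound 3 and compound 4 it is bound to an amine nitrogen. The measured pair gives no readable size for this kind of step, and compound 3 already stands close to the limit. Compound 4 is therefore expected to show a small step, a 1.2-fold higher number from compound 3 to compound 4 (0.09 log units; within the scatter), resting on the unreadable step from compound 2 to compound 1 and on compound 3 at 57500 nM. For compound 4 the estimate in this assay is 70000 nM, between 30000 nM and 150000 nM, with a real chance that only a limit is reported.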

Compound 4, half-maximal cytotoxic concentration: 77600 nM
Compound 4: middle estimate off by 1.1-fold (0.04 log units), on the low side; the measured number falls inside the stated range.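

In this assay, the change from methyl to hydrogen on the saturated chain carbon bound to an amine nitrogen and an aromatic carbon gives a 1.3-fold higher number from compound 3 to compound 4 (0.13 log units; within the scatter), so on the core of compound 3 this step cannot be told apart from the usual spread of repeated measurements. Going by these compounds alone, the same kind of change on the core of compound 2, where the carbon is bound to an amide-type nitrogen, cannot be read, because compound 2 and compound 1 each stand at a limit of the test rather than at a number: the limit of > 100000 nM in this assay, at which 2 of the 4 values shown sit. With a size for only one of the two steps, the data neither show that the change carries over from one core to the other nor show that it fails to, and the two places are in any case not identical.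

The compounds shown leave open how this assay responds to other groups on this carbon, such as an ethyl or a hydroxymethyl in place of the methyl. They also leave open what a carboxylic acid, or a chain longer than propyl, would give in place of the propylcarbamoyl group on the core of compound 4.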